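Nitro for chloro on the core of compound 3

A few compounds are considered here, and "the series" means these few. Any claim that something is new, unique, unknown or untested is made for them only; others in the source may bear on it.

Among the measured compounds shown here, compound 3 `O=C(NN=C1CC(c2ccccc2)NC(c2ccccc2)C1)c1ccc(Cl)cc1` gives 67900 nM in a functional assay, read by spectrophotometry (on this read-out lower numbers stand for stronger inhibition and higher numbers for weaker inhibition), the highest of the three numbers so far. Compound 1 `CCOC(=O)N1CCC(=NNC(=O)c2ccc(Cl)cc2)CC1` gives 63900 nM, within the scatter of compound 3; compound 2 `CCOC(=O)N1CCC(=NNC(=O)c2ccc(C(F)(F)F)cc2)CC1` gives 23500 nM, and the gap from compound 3 to compound 2 lies beyond the scatter. Compound 4 `O=C(NN=C1CC(c2ccccc2)NC(c2ccccc2)C1)c1ccc([N+](=O)[O-])cc1` differs from compound 3 by nitro in place of chloro on an aromatic carbon. For the measured compounds named here, the only measured step that bears on a change at this place is a 2.7-fold lower number from compound 1 to compound 2 (0.43 log units; beyond the scatter), made on a different core; it shows that exchanging the chloro there can lower the number modestly. Going by the values given here, no measured pair shows nitro in place of chloro, so the size of a nitro step is unknown. A modest drop in this assay is therefore expected, of a size comparable to that step, though no change beyond the scatter would also fit. Compound 4 is expected to give about 40000 nM, in the range 15000 nM to 110000 nM, which corresponds to an expected 1.7-fold lower number from compound 3 to compound 4 (0.23 log units; within the scatter).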

Compound 4, half-maximal inhibitory concentration: 170000 nM
Estimate against measurement, compound 4: 4.3-fold (0.63 log units) below; the whole stated range lies below it.
By their numbers in this assay, from the lowest: compound 2; then compounds 1 and 3 (each within the scatter of the next); then compound 4.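

In this assay the change from 4-chlorophenyl to 4-nitrophenyl gives a 2.5-fold higher number from compound 3 to compound 4 (0.40 log units; beyond the scatter) and so shows that an exchange of the chloro at this place can also raise the number. The earlier step, a 2.7-fold lower number from compound 1 to compound 2 (0.43 log units; beyond the scatter) with trifluoromethyl entering on a different core, runs the opposite way, so exchanging the chloro has no single direction across the two pairs, and these pairs differ in both the entering group and the core. Nothing available here bears on why nitro raises the number on the core of compound 3.

Still open, on these data alone, is whether the direction follows the entering group or the core, which nitro on the core of compound 1 or trifluoromethyl on the core of compound 3 would separate. Also open, as far as these compounds go, is how an amine or a carboxylic acid at this place would read.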